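A few compounds are considered here, and "the series" means these few. Any claim that something is new, unique, unknown or untested is made for them only; others in the source may bear on it.

Compound 1: `O=C(NC(=S)NNc1ncnc2ccccc12)c1ccc(Cl)cc1` gives 3940 nM
Compound 2: `O=C(NC(=S)NNc1ncnc2ccccc12)c1cccc(Cl)c1` gives 4740 nM

Both were tested in a functional assay on KB cells (Homo sapiens) for cytotoxicity, read by MTT assay, with a stated time of 72 h (on this read-out higher numbers stand for weaker inhibition and lower numbers for stronger inhibition), a measure of how strongly each compound holds back the growth of a cancer cell line. Among the measured compounds shown here, compound 2, with its 3-chlorophenyl group, sits alongside compound 1, the only other compound measured: the step of a 1.2-fold higher number from compound 1 to compound 2 (0.08 log units; within the scatter) lies within the scatter, so the two numbers cannot be told apart.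

Compound 3, `O=C(NC(=S)NNc1ncnc2ccccc12)c1ccccc1Cl`, is not yet measured. It differs from compound 2 in one place: 2-chlorophenyl in place of 3-chlorophenyl on a carbonyl carbon. The chlorine thus stays on the same phenyl ring and simply takes another position on it.

For the measured compounds named here, the only measured step that bears on this is the one from compound 1 to compound 2, which also moved the chlorine around the ring and changed nothing beyond the scatter. There is no further evidence for a shift in either direction. For compound 3 the expected step is therefore a 1.1-fold lower number from compound 2 to compound 3 (0.02 log units; within the scatter), a number barely moved from that of compound 2. The estimate for compound 3 is 4500 nM, with a range from 2000 nM to 10000 nM.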

Compound 3, half-maximal inhibitory concentration: 7710 nM
Compound 3: the middle estimate sits 1.7-fold (0.23 log units) below what was measured; measured number inside the range.
By their numbers in this assay, from the lowest: compounds 1, 2 and 3 (each within the scatter of the next).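

With 2-chlorophenyl now on the carbonyl carbon, the chlorine has been read in three different places on this phenyl ring in this assay, and the new compound gives a 1.6-fold higher number from compound 2 to compound 3 (0.21 log units; within the scatter) and a 2.0-fold higher number from compound 1 to compound 3 (0.29 log units; within the scatter). Both steps lie within the usual scatter, so compounds 1, 2 and 3 cannot be told apart, and across these three compounds moving the chlorine around the ring makes no readable difference, a conclusion the earlier pair could support for only two of its places. No separate measurement bears on these numbers, so nothing here can speak to what lies behind them.

From the compounds shown here alone, what stays open is whether the chlorine itself counts for anything, since all three compounds carry it on the phenyl ring and share the same core. A plain phenyl, a methoxy group or a carboxylic acid in place of the chlorine might read much the same in this assay or quite differently, and the compounds shown cannot say which.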